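Carbamoyl to methoxy: expected stability of compound 3

The source may hold more compounds than are shown below. What is called first, only, known or untested is meant among the compounds shown, and "the series" means these compounds.

In an ADME assay on microsomes from liver (Rattus norvegicus), read by LC-MS, using NADPH, with a stated time of 30 min, tested at 1 uM (a higher number here means that more of the compound is left, a lower number that less of the compound is left), compound 1 `Cc1c([C@H](C)Nc2nc(N)nc(N)c2C#N)c(-c2ccccc2)c(=O)n2cc(F)ccc12` gives 85%. In this assay compound 2 `C[C@H](Nc1nc(N)nc(N)c1C#N)c1c(-c2ccccc2)c(=O)n2cc(F)ccc2c1-c1ccc(C(N)=O)cc1` gives 100%, the higher of the two numbers, reached by a number 15 percentage points higher from compound 1 to compound 2 (beyond the scatter). Compound 3 `COc1ccc(-c2c([C@H](C)Nc3nc(N)nc(N)c3C#N)c(-c3ccccc3)c(=O)n3cc(F)ccc23)cc1` differs from compound 2 by methoxy in place of carbamoyl on an aromatic carbon. Within the data shown here, no measured step shows this exchange; the only measured step, a number 15 percentage points higher from compound 1 to compound 2 (beyond the scatter), concerns another part of the molecule and gives no guidance. Because compound 2 gives 100% at the top of the scale, compound 3 is expected to give 90%, within 72% to 100%. The expected step of a number 10 percentage points lower from compound 2 to compound 3 (within the scatter) lies within the scatter.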

Compound 3, percent of the compound remaining: 76%
Beside the measured number, compound 3's estimate is 14 percentage points above it; the range from low to high includes it.
By their numbers in this assay, from the lowest: compounds 3 and 1 (each within the scatter of the next); then compound 2.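

At this position on the aromatic ring, the group at the far end of the added ring matters: in this assay, methoxy in place of carbamoyl gives a number 24 percentage points lower from compound 2 to compound 3 (beyond the scatter). So the high number of compound 2 does not extend to every aryl group here. With 4-methoxyphenyl in place of methyl, the result is a number 9 percentage points lower from compound 1 to compound 3 (within the scatter), so only 4-carbamoylphenyl stands out from methyl. Nothing available explains this difference. From the compounds shown here alone, whether an amine, a carboxylic acid or a plain unsubstituted phenyl in this place would stay closer to compound 2 or to compound 3 remains open.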